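This account rests on a few compounds, and the source may have more. Where it says the series, first, only, none or still open, it means among the compounds named here.

For the measured compounds named here, compound 2 `Cn1nc2c(=O)n(CC3(O)CCN(Cc4ccc(-c5ccco5)cc4Cl)CC3)cnc2c1-c1ccc(CNCCO)cc1` and compound 1 `Cn1nc2c(=O)n(CC3(O)CCN(Cc4ccc(-c5ccco5)cc4Cl)CC3)cnc2c1-c1ccc(CNC=O)cc1` share the same core and differ in only one group on an amine nitrogen. In an ADME assay on Caco-2 cells (Homo sapiens) for permeability, in the apical to basolateral direction (a lower number here means that the compound crosses the layer more slowly, a higher number that the compound crosses the layer faster), compound 1 gives 0.65 10^-6 cm/s, and compound 2 gives 0.36 10^-6 cm/s. Between them lies a 1.8-fold lower number from compound 1 to compound 2 (0.26 log units; within the scatter), so compound 2 holds the lower of the two numbers without standing apart from compound 1. Compound 3 `Cn1nc2c(=O)n(CC3(O)CCN(Cc4ccc(-c5ccco5)cc4Cl)CC3)cnc2c1-c1ccc(CNS(C)(=O)=O)cc1` is the next member of the series: methylsulfonyl in place of 2-hydroxyethyl on an amine nitrogen. Going by the values given here, the one measured step swapped formyl for 2-hydroxyethyl on that same nitrogen and stayed within the scatter; no measured pair exchanges 2-hydroxyethyl for methylsulfonyl, so nothing here argues for a large move in either direction. The expectation for compound 3 in this assay is therefore a step of a 1.4-fold higher number from compound 2 to compound 3 (0.14 log units; within the scatter), no larger than the scatter. Compound 3 is expected to give about 0.5 10^-6 cm/s, within a range from 0.2 10^-6 cm/s to 1.3 10^-6 cm/s.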

Compound 3, apparent permeability: 50 10^-6 cm/s
Estimate against measurement, compound 3: 100-fold (2.00 log units) below; the measured number lies above the stated range.
By their numbers in this assay, from the lowest: compounds 2 and 1 (each within the scatter of the next); then compound 3.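

In this assay, the group on this amine nitrogen proves able to shift the number strongly: methylsulfonyl in place of 2-hydroxyethyl gives a 140-fold higher number from compound 2 to compound 3 (2.14 log units; beyond the scatter) and methylsulfonyl in place of formyl gives a 77-fold higher number from compound 1 to compound 3 (1.89 log units; beyond the scatter) in the same series. The swap between formyl and 2-hydroxyethyl stayed within the scatter, so only the third group reveals how much this position can matter, and since the three compounds differ in this one place, the large steps belong to this change. No measurement shown here gives a reason for the jump.

As far as these compounds go, it remains open whether the high number is special to methylsulfonyl or would also appear with a close relative on this nitrogen, such as ethylsulfonyl or acetyl. From the compounds shown here alone, it also remains open whether the same change would act alike on a different core.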